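The source may hold more compounds than are shown below. What is called first, only, known or untested is meant among the compounds shown, and "the series" means these compounds.

Compound 1 `CN(CC(=O)N1CCN(c2ccccc2)CC1)C(=O)c1ccc(S(C)(=O)=O)c([N+](=O)[O-])c1`: > 60000 nM
Compound 2 `CC1CCN(C(=O)CCNC(=O)c2ccc(S(C)(=O)=O)c([N+](=O)[O-])c2)CC1`: > 60000 nM
Compound 3 `CN(CC(=O)N1CCN(c2ccc(C(F)(F)F)cc2)CC1)C(=O)c1ccc(S(C)(=O)=O)c([N+](=O)[O-])c1`: > 60000 nM

Each of these figures in an assay on isolated protein for inhibition of thyroid hormone receptor beta (Homo sapiens), read by fluorescence polarization (on this read-out lower numbers stand for stronger inhibition and higher numbers for weaker inhibition), is a limit of the assay rather than a number. Compound 2 therefore stands only at that limit, and the two other compounds stand there with it. Among the compounds with values here, the single measured step, a step that the two limits leave unreadable from compound 1 to compound 3, is unreadable for the same reason and concerns a different change on the shared core. Compound 4 `CS(=O)(=O)c1ccc(C(=O)NCCC(=O)N2CCCCC2)cc1[N+](=O)[O-]` differs from compound 2 by hydrogen in place of methyl on a saturated ring carbon. Within the data shown here, no measured step speaks to this change, and because the limit of > 60000 nM in this assay, at which 3 of the 3 values shown sit, is where every value shown sits, compound 4 is expected to remain at the limit in this assay as well, with a step that the limit leaves unreadable from compound 2 to compound 4 of no readable size. The estimate for compound 4 is 80000 nM, with a range from 30000 nM to 250000 nM.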

Compound 4, half-maximal inhibitory concentration: > 60000 nM
Compound 4: only a limit was reported; the forecaster's own chance of this, stated with the estimate: 85%; the middle value does not contradict the limit.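

Within the data shown here, compound 2 and compound 4 both stand only at a limit of the assay, so no step between them can be read. The compounds shown leave open which structural change, if any, would give a measurable value in this assay.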